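A few compounds are considered here, and "the series" means these few. Any claim that something is new, unique, unknown or untested is made for them only; others in the source may bear on it.

Compound 1 `CCOc1cccc2cc(-c3ccccc3)c(=O)oc12` — in a functional assay on CHO cells for antagonist activity at adenosine receptor A2b (Homo sapiens), read by cAMP accumulation (a higher number here means a weaker inhibitor, a lower number a stronger inhibitor), compound 1 gives > 30000 nM, a limit of the assay and not a number.
Compound 2 `CCOc1cccc2cc(-c3ccc(Br)cc3)c(=O)oc12` — in this assay compound 2 gives > 30000 nM, likewise a limit and not a number.

Compound 2 thus stands at the limit, with no number of its own. Compound 3 `CCOc1cccc2cc(-c3ccc(OC)cc3)c(=O)oc12` differs from it by methoxy in place of bromo on an aromatic carbon. Among the measured compounds shown here, the only measured step, a step that the two limits leave unreadable from compound 1 to compound 2, offers no readable size because of the limit of > 30000 nM in this assay, at which 2 of the 2 values shown sit. No step beyond the scatter can be expected from it. Compound 3 is estimated at 30000 nM, in the range 8000 nM to 100000 nM. The expected step of a number no higher from compound 2 to compound 3 (the limit leaves the size open) therefore means no change beyond the scatter.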

Compound 3, half-maximal inhibitory concentration: > 30000 nM
Compound 3 ended at the assay's limit; the forecaster's own chance of this, stated with the estimate: 85%; the middle value lies on the limit itself.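

No step from compound 1 or compound 2 to compound 3 can be read in this assay, because all three compounds stand at a limit and not at a number: the limit of > 30000 nM in this assay, at which 3 of the 3 values shown sit.

The compounds shown leave open whether hydrogen, bromo and methoxy on that aromatic carbon differ at all in this assay.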